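The source may hold more compounds than are shown below. What is called first, only, known or untested is meant among the compounds shown, and "the series" means these compounds.

Compound 1 `CC(C(=O)N1CC2CC2C1)N1CCN(S(=O)(=O)c2ccc(C(C)(C)C)cc2)CC1`: in an ADME assay on HepG2 cells (Homo sapiens) for inhibition, with a stated time of 48 h (on this read-out higher numbers stand for an effect only at larger amounts of compound and lower numbers for an effect already at smaller amounts), compound 1 gives > 40000 nM, a limit of the assay.
Compound 2 `CC(C(=O)N1CCCCCC1)N1CCN(S(=O)(=O)c2ccc(C(C)(C)C)cc2)CC1`: in this assay compound 2 gives > 40000 nM, likewise a limit.
Compound 3 `C[C@@H](C(=O)N1CCC(F)(F)CC1)N1CCN(S(=O)(=O)c2ccc(C(C)(C)C)cc2)CC1`: in this assay compound 3 gives > 40000 nM, again a limit.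

Compound 2 therefore stands at the limit, and the two other values shown are limits as well, as the limit of > 40000 nM in this assay, at which 3 of the 3 values shown sit, records. Among the measured compounds shown here, the only measured step, a step that the two limits leave unreadable from compound 1 to compound 2, cannot be read because the limit of > 40000 nM in this assay, at which 3 of the 3 values shown sit, holds at both of its ends. Compound 4 `CC(C(=O)N1CCOCC1)N1CCN(S(=O)(=O)c2ccc(C(C)(C)C)cc2)CC1` differs from compound 2 by morpholin-4-yl in place of azepan-1-yl on a carbonyl carbon. No readable step bears on this change, so no direction can be drawn from the measured compounds. The expected step in this assay is a step that the limit leaves unreadable from compound 2 to compound 4, nothing beyond the scatter, and most likely another limit. Compound 4 is estimated at 80000 nM, between 25000 nM and 250000 nM.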

Compound 4, half-maximal effective concentration: > 40000 nM
Compound 4 ended at the assay's limit; the forecaster's own chance of this, stated with the estimate: 85%; the middle value lies beyond the limit too.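

Neither step to compound 4, from compound 1 or from compound 2, can be read, because both ends of each sit at one limit: the limit of > 40000 nM in this assay, at which 4 of the 4 values shown sit. The compounds shown leave open what their actual values in this assay are.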